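Stilbene Amides Against A549 Cells: Estimating a Piperidine Analogue

The source may report more compounds than this note shows. Statements on the series, on what has been measured and on what is new or still open speak of the compounds shown alone.

Measured so far:
Compound 1 `COc1ccc(/C=C/c2cc(OC)cc(OC)c2/C=C/C(=O)NC2CC2)cc1` gives 8810 nM in a functional assay on A549 cells (Homo sapiens) for inhibition, read by MTT assay, with a stated time of 48 h; a lower number here means a stronger inhibitor, a higher number a weaker inhibitor.
Compound 2 `CCC(C)NC(=O)/C=C/c1c(/C=C/c2ccc(OC)cc2)cc(OC)cc1OC` gives 3950 nM in this assay.
Compound 3 `COc1ccc(/C=C/c2cc(OC)cc(OC)c2/C=C/C(=O)N2CCCC2)cc1` gives 6350 nM in this assay.

Compound 1 has the highest number of the three, so it is the weakest inhibitor among them. Compound 4 `COc1ccc(/C=C/c2cc(OC)cc(OC)c2/C=C/C(=O)N2CCC(c3ccccc3)CC2)cc1` differs from compound 1 by 4-phenylpiperidin-1-yl in place of cyclopropylamino on a carbonyl carbon. Among the measured compounds shown here, two measured steps bear on this: a 2.2-fold lower number from compound 1 to compound 2 (0.35 log units; beyond the scatter) and a 1.4-fold lower number from compound 1 to compound 3 (0.14 log units; within the scatter). For the measured compounds named here, replacing the cyclopropylamino group lowered the number modestly or not beyond the scatter, with no example of a large gain. A similar modest lowering is expected for compound 4, giving an estimated step of a 1.8-fold lower number from compound 1 to compound 4 (0.25 log units; within the scatter). Compound 4 is therefore estimated at 5000 nM, with a range from 2000 nM to 14000 nM.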

Compound 4, half-maximal inhibitory concentration: 6690 nM
For compound 4 the middle estimate is 1.3-fold (0.13 log units) below the measured one; the measured number falls inside the stated range.
By their numbers in this assay, from the lowest: compounds 2, 3, 4 and 1 (each within the scatter of the next, the first and the last beyond it).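

Even 4-phenylpiperidin-1-yl, with 12 heavy atoms against 4 for cyclopropylamino and an added aromatic ring, gives only a 1.3-fold lower number from compound 1 to compound 4 (0.12 log units; within the scatter). Measured against the other two amides, it gives a 1.1-fold higher number from compound 3 to compound 4 (0.02 log units; within the scatter) and a 1.7-fold higher number from compound 2 to compound 4 (0.23 log units; within the scatter), so this carbonyl carbon takes a much larger group with no step beyond the scatter. Nothing shown here gives a reason for this. Still open, from the compounds shown here alone, is whether an amide carrying a carboxylic acid, a free amine or a longer chain would move the number beyond the scatter.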